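Butyl to propyl on the shared core: expected antiproliferative read-out

The source may report more compounds than this note shows. Statements on the series, on what has been measured and on what is new or still open speak of the compounds shown alone.

Measured compounds:
compound 1 `CCCCn1cnc2c(NCc3ccc(C(=O)Nc4ccccc4N)cc3)nc(Cl)nc21` — 6.8%
compound 2 `Nc1ccccc1NC(=O)/C=C/c1ccc(Cn2cnc3c(NC4CCCCC4)nc(Cl)nc32)cc1` — 3.83%

In a functional assay on HepG2 cells (Homo sapiens) for antiproliferative activity, read by CCK-8 assay, with a stated time of 72 h, tested at 2 uM (on this read-out lower numbers stand for a weaker effect and higher numbers for a stronger effect at the one concentration tested), compound 1 gives 6.8% and stands at the top of the two numbers shown; compound 2, however, gives 3.83%, a gap that lies within the scatter, so the two cannot be told apart and both sit near the bottom of the scale.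

Compound 3 `CCCn1cnc2c(NCc3ccc(C(=O)Nc4ccccc4N)cc3)nc(Cl)nc21` differs from compound 1 in one place: hydrogen in place of methyl on a saturated chain carbon, three bonds along the chain from an aromatic nitrogen. Among the compounds with values here, no measured pair shows a step of this kind, so the numbers themselves give no direction for it. With both measured compounds this weak, no step beyond the scatter is expected in this assay; the estimated step is a number 0.8 percentage points lower from compound 1 to compound 3 (within the scatter), essentially none. Compound 3 is therefore expected to give 6% in this assay, with a range from 0% to 14%.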

Compound 3, a percentage reported as inhibition, at one concentration (the size of the read-out at that concentration, not a potency): 12.4%
Compound 3: middle estimate off by 6.4 percentage points, on the low side; the measured number falls inside the stated range.
By their numbers in this assay, from the lowest: compounds 2, 1 and 3 (each within the scatter of the next).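

Working notes on the chain: in this assay the change from butyl to propyl, with hydrogen in place of methyl on a saturated chain carbon, three bonds along the chain from an aromatic nitrogen, gives a number 5.6 percentage points higher from compound 1 to compound 3 (within the scatter). Within the data shown here, this is the first reading at this position, and it shows that losing this methyl leaves the read-out within the scatter; a single step of this size assigns no direction to the change, and compound 3 at 12.4% remains a small effect at the one concentration tested. No measured evidence bears on the reason for this result.

From the compounds shown here alone, whether an ethyl or methyl group, a longer chain such as hexyl, or a chain ending in an amine or a carboxylic acid would move the read-out beyond the scatter stays open. Compound 2 differs from compound 3 in more than one place, so it adds nothing on this position.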